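Amide variation on a dimethoxy-indane acetamide series

A few compounds are considered here, and "the series" means these few. Any claim that something is new, unique, unknown or untested is made for them only; others in the source may bear on it.

Measured so far:
compound 1 `CCN(CC)C(=O)CC1CCc2cc(OC)c(OC)cc21` — 16.7%
compound 2 `CCCCCNC(=O)CC1CCc2cc(OC)c(OC)cc21` — 46.7%
compound 3 `COc1cc2c(cc1OC)C(CC(=O)NC1CCCCC1)CC2` — 53.3%

The read-out is a functional assay on the whole organism (strain Wistar) for inhibition, with Rattus norvegicus as the target, read by paw edema, with stated times of 60 min and 24 h, at a dose of 100 mg/kg by the oral route; on this read-out higher numbers stand for more inhibition at the one dose given (going by the name of the read-out) and lower numbers for less inhibition. Compound 2 stands second of the three numbers: compound 3 sits a number 6.6 percentage points higher from compound 2 to compound 3 (within the scatter), a gap that means nothing here, while compound 1 lies well apart, the step being a number 30 percentage points higher from compound 1 to compound 2 (beyond the scatter). Among the measured compounds shown here, compound 1 is the one measured compound without an amide hydrogen, and both steps away from it are the sizable ones, a number 30 percentage points higher from compound 1 to compound 2 (beyond the scatter) and a number 36.6 percentage points higher from compound 1 to compound 3 (beyond the scatter).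

Compound 4 `COc1cc2c(cc1OC)C(CC(=O)N1CCNCC1)CC2` differs from compound 2 in one place: piperazin-1-yl in place of pentylamino on a carbonyl carbon. Like compound 1, compound 4 has no amide hydrogen, so the step that bears most on it is the one from compound 1, read backwards, a number 30 percentage points higher from compound 1 to compound 2 (beyond the scatter). The two steps that did involve a secondary amide, a number 6.6 percentage points higher from compound 2 to compound 3 (within the scatter), give no further guidance. For the measured compounds named here, on this basis a drop of similar size is expected, though the new ring with its own hydrogen-bond donor has no precedent among the measured compounds, so the range must be wide. For compound 4 the estimated step is a number 21.7 percentage points lower from compound 2 to compound 4 (beyond the scatter). Compound 4 is therefore estimated at 25%, with a likely range from 5% to 50%.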

Compound 4, a percentage reported as inhibition, in the whole organism at one dose (the size of the read-out at that dose, not a potency): 65%
For compound 4 the middle estimate is 40 percentage points below the measured one; measured number above the stated range.
By their numbers in this assay, from the lowest: compound 1; then compounds 2 and 3 (each within the scatter of the next); then compound 4.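

The low number of compound 1 cannot be taken as a feature of all amides without an amide hydrogen: compound 4 also lacks that hydrogen, yet the change from diethylamino to piperazin-1-yl gives a number 48.3 percentage points higher from compound 1 to compound 4 (beyond the scatter) on the same carbonyl carbon. The ring also exceeds both amides that keep the hydrogen, with a number 18.3 percentage points higher from compound 2 to compound 4 (beyond the scatter) and a number 11.7 percentage points higher from compound 3 to compound 4 (beyond the scatter), so compound 4 stands highest of the measured compounds and neither pentylamino nor cyclohexylamino marks the upper level at this position. No accompanying measurement bears on this result, so the rise stays unexplained.

Whether the gain comes from the six-membered ring itself or from its second nitrogen remains unresolved; morpholin-4-yl, with oxygen at that place, or piperidin-1-yl, with carbon there, would separate the two. Also open, as far as these compounds go, is whether a methyl or acetyl group on that nitrogen keeps the number, and a single oral dose gives the size of the effect without any measure of potency.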